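A Nitrile Takes the Place of Bromine

The compounds below may be only part of what the source reports. "The series", "measured", "known", "first", "only" and "open" are said of these compounds alone.

Compound 2 `CC(C(=O)NCc1ccc(C(C)(C)C)cc1)c1ccc(NS(C)(=O)=O)c(Br)c1` gives the lowest number of the three compounds measured in an assay on CHO cells for displacement of a labelled ligand from transient receptor potential cation channel subfamily V member 1 (Rattus norvegicus), read by scintillation counting, with a stated time of 60 min (a lower number here means a stronger inhibitor, a higher number a weaker inhibitor), at 7.4 nM. Compound 3 `CC(C(=O)NCc1ccc(C(C)(C)C)cc1)c1cc(F)c(NS(C)(=O)=O)c(F)c1` gives 19.9 nM, and compound 1 `CC(C(=O)NCc1ccc(C(C)(C)C)cc1)c1ccc(NS(C)(=O)=O)cc1` gives 106 nM. Going by the values given here, the one step measured between neighbours, a 14-fold lower number from compound 1 to compound 2 (1.16 log units; beyond the scatter), shows how much a single group on this ring can matter. Compound 4 `CC(C(=O)NCc1ccc(C(C)(C)C)cc1)c1ccc(NS(C)(=O)=O)c(C#N)c1` differs from compound 2 by cyano in place of bromo on an aromatic carbon. Among the compounds with values here, no measured step tells what a cyano group does at this place, so the expectation rests on compound 1 and compound 2, whose step a 14-fold lower number from compound 1 to compound 2 (1.16 log units; beyond the scatter) suggests a cyano group may keep part of that gain. Compound 4 is therefore expected at 15 nM, within 5 nM to 50 nM, an expected step of a 2.0-fold higher number from compound 2 to compound 4 (0.31 log units; beyond the scatter).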

Compound 4, inhibition constant: 344 nM
Compound 4: the middle estimate sits 23-fold (1.36 log units) below what was measured; the whole stated range lies below it.
By their numbers in this assay, from the lowest: compound 2; then compound 3; then compound 1; then compound 4.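

Swapping bromo for cyano at this place brings a 46-fold higher number from compound 2 to compound 4 (1.67 log units; beyond the scatter) and so undoes the gain that bromo gave. Cyano in place of hydrogen brings a 3.2-fold higher number from compound 1 to compound 4 (0.51 log units; beyond the scatter) in this assay, so a group at this place can move the number either way from that of compound 1. Nothing at hand explains why these two groups part so sharply.

The compounds shown leave open how chloro, methyl or an amine would fare at this place, and so whether bromo or cyano is the exception among such groups.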